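This account rests on a few compounds, and the source may have more. Where it says the series, first, only, none or still open, it means among the compounds named here.

Of the compounds shown here, three built on one shared core have so far been tested in a functional assay on HeLa cells (Homo sapiens) for inhibition, read by MTT assay, with a stated time of 48 h; on this read-out lower numbers stand for stronger inhibition and higher numbers for weaker inhibition. Compound 1 `CCOC(=O)C1=C(N/C=N/c2nnc(S(N)(=O)=O)s2)Nc2[nH]nc(C)c2C1c1ccc(N(C)C)cc1` gives 26300 nM in this assay. Compound 2 `CCOC(=O)C1=C(N/C=N/c2ccccn2)Nc2[nH]nc(C)c2C1c1ccc(N(C)C)cc1` gives 29200 nM. Compound 3 `CCOC(=O)C1=C(N/C=N/c2ccc([N+](=O)[O-])cc2)Nc2[nH]nc(C)c2C1c1ccc(N(C)C)cc1` gives 57800 nM. Compound 3 thus carries the highest of the three numbers, though only narrowly: the step of a 2.0-fold higher number from compound 2 to compound 3 (0.30 log units; within the scatter) lies within the scatter, while the step of a 2.2-fold higher number from compound 1 to compound 3 (0.34 log units; beyond the scatter) is modest but just beyond it.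

Compound 4 `CCOC(=O)C1=C(N/N=C(/C(C)=O)C(=O)OCC)Nc2[nH]nc(C)c2C1c1ccc(N(C)C)cc1` has not yet been measured. It differs from compound 3 on an amine nitrogen whose other neighbour is a double-bonded ring carbon: a group of 10 heavy atoms (6 carbon, 1 nitrogen, 3 oxygen; no ring) in place of a group of 11 heavy atoms (7 carbon, 2 nitrogen, 2 oxygen; one six-membered aromatic ring of carbon only), on an amine nitrogen. Among the measured compounds shown here, none of the measured steps matches this change, since each of them exchanges one group containing a ring for another on a double-bonded nitrogen, whereas the group entering here has no ring. What they do show is that exchanges at this position moved the number by no more than a 2.2-fold higher number from compound 1 to compound 3 (0.34 log units; beyond the scatter), and that a 1.1-fold higher number from compound 1 to compound 2 (0.05 log units; within the scatter) stayed within the scatter. On that basis only a small step is expected, with no clear direction. For compound 4 the step is expected to be a 1.2-fold lower number from compound 3 to compound 4 (0.06 log units; within the scatter). Compound 4 is therefore estimated at 50000 nM, within a range from 18000 nM to 140000 nM.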

Compound 4, half-maximal inhibitory concentration: > 100000 nM
Compound 4 was reported as a limit; the forecaster's own chance of this, stated with the estimate: 20%; at least 2.0-fold (0.30 log units) between middle value and limit.
By their numbers in this assay, from the lowest: compounds 1, 2 and 3 (each within the scatter of the next, the first and the last beyond it). At a limit, above all of these: compound 4.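

In this assay, compound 4 gives no number but only a limit: the limit of > 100000 nM in this assay, at which 1 of the 4 values shown sits.

Counted from that limit as a floor, an at least 3.4-fold higher number from compound 2 to compound 4 (0.53 log units; beyond the scatter) and an at least 3.8-fold higher number from compound 1 to compound 4 (0.58 log units; beyond the scatter) both lie beyond the scatter and exceed the largest step among the earlier compounds, a 2.2-fold higher number from compound 1 to compound 3 (0.34 log units; beyond the scatter), whereas the floor of an at least 1.7-fold higher number from compound 3 to compound 4 (0.23 log units; that floor lies within the scatter) remains within the scatter and alone shows no firm separation. The exchanges among groups containing a ring had therefore understated how far this position can move the read-out, since the group with no ring, on an amine nitrogen, gives a result beyond any of theirs against compounds 1 and 2.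

From the compounds shown here alone, how far compound 4 lies past its limit cannot be read, so the true size of all three steps stays unknown, and a single compound cannot separate the loss of the ring from the other differences between the groups. The compounds shown also leave open whether an open chain ending in an amine or a carboxylic acid would return a measurable number, or whether a plain phenyl ring would stay with compounds 1, 2 and 3.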